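Ortho substituent swap on a thiourea series: trifluoromethyl to methyl

The source may report more compounds than this note shows. Statements on the series, on what has been measured and on what is new or still open speak of the compounds shown alone.

Two compounds share one core and differ only in the group carried on the aryl ring of the thiourea. Compound 1 `NC(=O)c1c(NC(=O)c2ccccc2Cl)sc2c1CCN(C(=S)Nc1ccccc1I)C2` carries an iodo group there, and in a functional assay on MKN-74 cells (Homo sapiens) for antiproliferative activity, with a stated time of 24 h (a higher number here means a weaker inhibitor, a lower number a stronger inhibitor), compound 1 gives 2630 nM. Compound 2 `NC(=O)c1c(NC(=O)c2ccccc2Cl)sc2c1CCN(C(=S)Nc1ccccc1C(F)(F)F)C2` carries a trifluoromethyl group instead, and in this assay compound 2 gives 1870 nM. Among the compounds with values here, the only measured step, a 1.4-fold lower number from compound 1 to compound 2 (0.15 log units; within the scatter), shows that exchanging these two groups left the activity essentially unchanged.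

Compound 3 `Cc1ccccc1NC(=S)N1CCc2c(sc(NC(=O)c3ccccc3Cl)c2C(N)=O)C1` takes the next step on the same ring: methyl in place of trifluoromethyl on an aromatic carbon. Nothing has yet been measured for this compound in this assay. Within the data shown here, the one step that bears on it, a 1.4-fold lower number from compound 1 to compound 2 (0.15 log units; within the scatter), tells that the aryl position tolerated a substantial change without a shift beyond the scatter. On that basis no step beyond the scatter is expected for compound 3 either, and the step of a 1.2-fold higher number from compound 2 to compound 3 (0.07 log units; within the scatter) is my estimate. Compound 3 is therefore expected to give about 2200 nM in this assay, within a range from 900 nM to 5500 nM.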

Compound 3, half-maximal inhibitory concentration: 11700 nM
Compound 3: the middle estimate sits 5.3-fold (0.73 log units) below what was measured, and the stated range ends below it.
By their numbers in this assay, from the lowest: compounds 2 and 1 (each within the scatter of the next); then compound 3.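

The aryl group on the thiourea turns out not to be indifferent: in this assay methyl in place of trifluoromethyl gives a 6.3-fold higher number from compound 2 to compound 3 (0.80 log units; beyond the scatter) and methyl in place of iodo gives a 4.4-fold higher number from compound 1 to compound 3 (0.65 log units; beyond the scatter), both beyond the usual scatter. The earlier pair suggested that this site accepts quite different groups, but with three compounds the picture changes, as iodo and trifluoromethyl stay within the scatter of each other while methyl stands apart from both as the weaker inhibitor. No measurement is available that explains why methyl behaves differently from the other two groups.

Within the data shown here, with only three groups on this carbon, it remains open whether methyl is a lone exception or marks a broader trend, and a chloro, a methoxy or an amino group, or a plain hydrogen, would help to settle this. Going by these compounds, it is also open whether the same order would hold with the group on a different carbon of the aromatic ring, since all three compounds carry it at the same place.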